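This account rests on a few compounds, and the source may have more. Where it says the series, first, only, none or still open, it means among the compounds named here.

Three urea-bearing analogues that share one core have been measured in a functional assay on SF-539 cells (Homo sapiens) for inhibition, read by sulforhodamine B assay, with a stated time of 48 h, tested at 1 uM; on this read-out lower numbers stand for a stronger effect and higher numbers for a weaker effect at the one concentration tested. Compound 1 `COc1cc(Cl)cc(-c2nn(-c3cccc(NC(=O)Nc4ccc(Cl)c(C(F)(F)F)c4)c3)cc2-c2ccncc2)c1` gives 75%, compound 2 `COc1cc(Cl)cc(-c2nn(-c3cccc(NC(=O)Nc4cc(C(F)(F)F)cc(C(F)(F)F)c4)c3)cc2-c2ccncc2)c1` gives 59%, and compound 3 `COc1cc(Cl)cc(-c2nn(-c3cccc(NC(=O)Nc4ccc(Cl)c(Cl)c4)c3)cc2-c2ccncc2)c1` gives 82%. Compound 3 therefore shows the highest number of the three, meaning the weakest effect at the single concentration tested. Its nearest neighbour is compound 1: the step of a number 7 percentage points higher from compound 1 to compound 3 (within the scatter), brought about by chloro in place of trifluoromethyl on an aromatic carbon, lies within the scatter, so the two cannot be told apart. Compound 2 sits furthest away, and the gap between its value and that of compound 3 is beyond the scatter.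

Compound 4 `COc1cc(Cl)cc(-c2nn(-c3cccc(NC(=O)Nc4cccc(C(F)(F)F)c4)c3)cc2-c2ccncc2)c1` has not yet been measured. Its difference from compound 3 is 3-(trifluoromethyl)phenyl in place of 3,4-dichlorophenyl on an amide-type nitrogen. Within the data shown here, only one measured step bears on this change, the swap of a single chloro for a trifluoromethyl from compound 1 to compound 3, and that step stayed within the scatter. Among the measured compounds shown here, the present change removes a chloro altogether rather than exchanging one group for another, so no measured pair matches it closely. On that basis, compound 4 is expected to land close to compound 3, with the step of a number 4 percentage points lower from compound 3 to compound 4 (within the scatter) estimated to fall within the scatter. The estimate for compound 4 in this assay is 78%, ranging from 60% to 95%.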

Compound 4, a percentage reported as activity, at one concentration (the size of the read-out at that concentration, not a potency): 84%
For compound 4 the middle estimate is 6 percentage points below the measured one; the measured number falls inside the stated range.
By their numbers in this assay, from the lowest: compound 2; then compounds 1, 3 and 4 (each within the scatter of the next).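

Replacing the whole aryl group changes little: a number 2 percentage points higher from compound 3 to compound 4 (within the scatter) in this assay, so 3-(trifluoromethyl)phenyl and 3,4-dichlorophenyl on the amide-type nitrogen cannot be told apart at this one concentration. The two single removals on this ring differ in outcome, since a number 9 percentage points higher from compound 1 to compound 4 (within the scatter) for hydrogen in place of chloro, whereas a number 25 percentage points higher from compound 2 to compound 4 (beyond the scatter) for hydrogen in place of trifluoromethyl, so among these compounds only the second trifluoromethyl of compound 2 goes with a clearly stronger effect. Nothing among the data given accounts for this difference between the two removals.

The compounds shown leave open how a plain phenyl, with no group on the ring, would compare, and whether a methoxy, a nitrile or an amine on this ring could match the effect seen with compound 2. They also leave open whether the gap between compound 2 and compound 4 would hold at other concentrations, as one concentration gives the size of an effect and not a potency.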